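The compounds below may be only part of what the source reports. "The series", "measured", "known", "first", "only" and "open" are said of these compounds alone.

In an in vitro ADME assay on microsomes from liver (Homo sapiens) for metabolic stability (a higher number here means that the compound lasts longer, a lower number that the compound disappears faster), compound 1 `CC(C)[C@H]1C(O)=C(C2=NS(=O)(=O)c3c(OCC(N)=O)cccc32)C(=O)N1Cc1ccccc1` gives > 1 h, which is a limit of the assay and not a number. Compound 2 `CC(C)[C@H]1C(O)=C(C2=NS(=O)(=O)c3c(OCC(=O)N4CCOCC4)cccc32)C(=O)N1Cc1ccccc1` gives > 1 h, which is likewise only a limit. Compound 2 therefore has no exact position, and the whole picture so far is the limit of > 1 h in this assay, at which 2 of the 2 values shown sit.

Compound 3 `CC(C)[C@H]1C(O)=C(C2=NS(=O)(=O)c3c(OCc4ncon4)cccc32)C(=O)N1Cc1ccccc1` keeps the shared core but changes the side chain, with 1,2,4-oxadiazol-3-yl in place of (morpholin-4-yl)carbonyl on a saturated chain carbon bound to an oxygen on an aromatic ring. For the measured compounds named here, the only measured step that bears on this change is a step that the two limits leave unreadable from compound 1 to compound 2. It swapped one group on a carbonyl carbon for another, whereas compound 3 loses the carbonyl altogether, so the step is a loose guide, and it offers no size or direction to carry over.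

The expected change is a step that the limit leaves unreadable from compound 2 to compound 3, with no step beyond the scatter and no firm direction expected in this assay. For compound 3 the estimated half-life is 1.5 h, with an expected range from 0.6 h to 4 h.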

Compound 3, half-life: > 1 h
Compound 3: a limit, no number (the forecaster's own chance of this, stated with the estimate: 70%); the middle value lies beyond the limit too.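

In this assay compound 3 gives > 1 h, which is again a limit and not a number. For the compounds shown here, no step among compound 1, compound 2 and compound 3 can therefore be read. The picture now stands at one point: the limit of > 1 h in this assay, at which 3 of the 3 values shown sit. Going by these compounds, how long each of these three compounds actually lasts stays open, as does whether changing the side chain alters that at all.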